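Methoxy for Fluoro in an Imidazoline Agonist Series

This account rests on a few compounds, and the source may have more. Where it says the series, first, only, none or still open, it means among the compounds named here.

This account follows a small set of imidazoline-bearing anilines tested in a functional assay for agonist activity at Alpha-1B adrenergic receptor (Homo sapiens); on this read-out higher numbers stand for an effect only at larger amounts of compound and lower numbers for an effect already at smaller amounts. Compound 2 `CSc1ccc(C)cc1NCC1=NCCN1` gives 0.417 nM in this assay. Compound 3 `CSc1ccc(F)cc1NCC1=NCCN1` gives 1.86 nM in this assay, the highest of the two numbers reported, with the step of a 4.5-fold higher number from compound 2 to compound 3 (0.65 log units; beyond the scatter) separating it from its nearest neighbour. Compound 1 `COc1ccc(S(C)(=O)=O)c(NCC2=NCCN2)c1` is reported in this assay only as a limit, < 100000 nM, not as a number (the limit of < 100000 nM in this assay, at which 1 of the 3 values shown sits).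

Compound 4 `COc1ccc(SC)c(NCC2=NCCN2)c1` is not yet measured. It differs from compound 3 by methoxy in place of fluoro on an aromatic carbon. Within the data shown here, no measured step covers a methoxy group taking the place of a fluoro group; the only step at that position is the one from methyl to fluoro, which raised the number by a modest amount. Compound 1 carries the same methoxy group with a methylsulfonyl group instead and sits at a limit, so it offers no number for comparison.

The number for compound 4 is therefore expected to change by a 1.9-fold lower number from compound 3 to compound 4 (0.27 log units; within the scatter), without leaving the range of the two measured neighbours. Compound 4 is estimated to give about 1 nM in this assay, between 0.3 nM and 5 nM.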

Compound 4, half-maximal effective concentration: 3.63 nM
Compound 4: middle estimate off by 3.6-fold (0.56 log units), on the low side; the range from low to high includes it.
By their numbers in this assay, from the lowest: compound 2; then compounds 3 and 4 (each within the scatter of the next).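

At the aromatic carbon para to a methylsulfanyl group, methoxy in place of fluoro leaves the read-out in this assay within the scatter, with a 2.0-fold higher number from compound 3 to compound 4 (0.29 log units; within the scatter), so the two groups cannot be told apart at this position. Against methyl the picture differs, with an 8.7-fold higher number from compound 2 to compound 4 (0.94 log units; beyond the scatter), so that methyl keeps the lowest number of the three groups compared here. The step from compound 1 to compound 4 cannot be read, because compound 1 stands at a limit: the limit of < 100000 nM in this assay, at which 1 of the 4 values shown sits.

The compounds shown leave open whether an amine, a hydroxyl group or a longer chain such as butoxy at this position would stay in the same range. They also leave open how much of a number the methylsulfonyl group would give with fluoro or methyl on the ring.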